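A few compounds are considered here, and "the series" means these few. Any claim that something is new, unique, unknown or untested is made for them only; others in the source may bear on it.

Among the measured compounds shown here, compound 3 `CCNC(=O)c1noc(-c2cc(C(C)C)c(O)cc2O)c1-c1cc(C(=O)O)no1` shows the highest of the two numbers so far in a functional assay on A2780 cells (Homo sapiens) for inhibition (on this read-out higher numbers stand for weaker inhibition and lower numbers for stronger inhibition), where compound 3 gives 20000 nM. For the measured compounds named here, its nearest neighbour is compound 2 `CCNC(=O)c1noc(-c2cc(C(C)C)c(O)cc2O)c1-c1cc(CN(CC)CC)no1`, which in this assay gives 78 nM; the single measured step runs a 260-fold higher number from compound 2 to compound 3 (2.41 log units; beyond the scatter). Compound 1 `CCNC(=O)c1noc(-c2cc(C(C)C)c(O)cc2O)c1-c1cc(CNC(=O)CC)no1`, which carries a propanamidomethyl group in the same position, gives "not determined" (no result reported) in this assay. Compound 4 `CCNC(=O)c1noc(-c2cc(C(C)C)c(O)cc2O)c1-c1cnn(CC)c1` differs from compound 3 in one place: 1-ethyl-1H-pyrazol-4-yl in place of 3-carboxy-1,2-oxazol-5-yl on an aromatic carbon. The measured step from compound 2 to compound 3 bears on this change only in part, since it removes the carboxy group but does not bring in the (diethylamino)methyl group of compound 2. With the carboxy group gone, compound 4 is expected to return much of the way toward the number of compound 2, and a step of a 50-fold lower number from compound 3 to compound 4 (1.70 log units; beyond the scatter) downward is estimated. Compound 4 is therefore expected to give about 400 nM in this assay, within a range from 60 nM to 3000 nM.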

Compound 4, half-maximal inhibitory concentration: 30 nM
Beside the measured number, compound 4's estimate is 13-fold (1.12 log units) above it; measured number outside the range, below it.
By their numbers in this assay, from the lowest: compound 4; then compound 2; then compound 3.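

In this assay, the change from 3-carboxy-1,2-oxazol-5-yl to 1-ethyl-1H-pyrazol-4-yl runs a 670-fold lower number from compound 3 to compound 4 (2.82 log units; beyond the scatter), which shows that this position, next to the ring atom that bears an ethylcarbamoyl group, accepts a different ring and not only a different group on the same ring. A low number here does not require the (diethylamino)methyl group of compound 2 at 78 nM, as compound 4 carries neither that group nor a carboxy group and gives 30 nM. The data shown offer no measured basis for explaining the size of this step.

The compounds shown do not separate the exchange of the ring from the loss of the carboxy group, a question on which an unsubstituted 1,2-oxazol-5-yl group would bear. They also leave open whether the ethyl group on the pyrazole could give way to a longer chain or an amine.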